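The compounds below may be only part of what the source reports. "The series", "measured", "known", "first", "only" and "open" are said of these compounds alone.

Compound 1 `C/C(=C\CC/C(C)=C/CC[C@@H]1[C@@]2(C)CCC(=O)C(C)(C)[C@H]2CC[C@@]1(C)O)CC/C=C(\C)C(=O)OCc1cn(-c2cccc(C)c2)nn1` bears a 3-methylphenyl on an aromatic nitrogen of a five-membered aromatic ring with 3 nitrogen, hung from the shared core. In a functional assay on DU-145 cells (Homo sapiens) for antiproliferative activity, read by MTT assay, with a stated time of 48 h (on this read-out higher numbers stand for weaker inhibition and lower numbers for stronger inhibition), compound 1 gives 137000 nM. Among the measured compounds shown here, that is the only plain number among the three measured compounds; the other two are limits of the assay. Compound 2 `C/C(=C\CC/C(C)=C/CC[C@@H]1[C@@]2(C)CCC(=O)C(C)(C)[C@H]2CC[C@@]1(C)O)CC/C=C(\C)C(=O)OCc1cn(C[C@@H]2O[C@H](n3ccc(=O)[nH]c3=O)[C@H]3OC(C)(C)O[C@H]32)nn1` carries a much larger group on that aromatic nitrogen, and in this assay compound 2 gives only the limit > 150000 nM. Compound 3 `C/C(=C\CC/C(C)=C/CC[C@@H]1[C@@]2(C)CCC(=O)C(C)(C)[C@H]2CC[C@@]1(C)O)CC/C=C(\C)C(=O)OCc1cn(-c2ccccc2Cl)nn1` carries 2-chlorophenyl in place of 3-methylphenyl on the aromatic nitrogen, and in this assay compound 3 likewise gives only the limit > 150000 nM. The step from compound 1 to compound 3 is an at least 1.0-fold higher number from compound 1 to compound 3 (0.03 log units; that floor lies within the scatter), so no change to the aryl group has so far moved the read-out beyond the scatter, and the limit of > 150000 nM in this assay, at which 2 of the 3 values shown sit, marks where most values sit.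

Compound 4 `C/C(=C\CC/C(C)=C/CC[C@@H]1[C@@]2(C)CCC(=O)C(C)(C)[C@H]2CC[C@@]1(C)O)CC/C=C(\C)C(=O)OCc1cn(-c2ccc(C(C)(C)C)cc2)nn1` is the next variation: 4-(tert-butyl)phenyl in place of 3-methylphenyl on an aromatic nitrogen. For the measured compounds named here, the only measured step that bears on this change, an at least 1.0-fold higher number from compound 1 to compound 3 (0.03 log units; that floor lies within the scatter), was small and pointed, if anywhere, toward weaker inhibition. The expected step of a 1.0-fold higher number from compound 1 to compound 4 (0.01 log units; within the scatter) is therefore within the scatter. In this assay compound 4 is expected to give about 140000 nM, in a range from 60000 nM to 300000 nM, with a real chance that only a limit is returned.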

Compound 4, half-maximal inhibitory concentration: > 150000 nM
Compound 4 gave a limit, no number (the forecaster's own chance of this, stated with the estimate: 55%); middle value at least 1.0-fold (0.02 log units) away from the limit.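

Putting 4-(tert-butyl)phenyl in place of 3-methylphenyl on the aromatic nitrogen in this assay gives an at least 1.0-fold higher number from compound 1 to compound 4 (0.03 log units; that floor lies within the scatter), so a second aryl change at this position has not been shown to move the read-out beyond the scatter. The steps between compounds that both end at a limit, such as compound 3 and compound 4, cannot be read, so the data do not rank those groups against each other. With compound 4 added, compound 2, compound 3 and compound 4 all end at the same limit and compound 1 is the lone exception, so this series now mostly meets the ceiling of the measurement rather than giving numbers to compare: the limit of > 150000 nM in this assay, at which 3 of the 4 values shown sit.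

Going by these compounds, whether a phenyl ring bearing an amine or a carboxylic acid, or a longer alkyl chain in place of the aryl group, would bring the read-out down to a plain number clearly beyond the scatter from compound 1 remains open. Also open, on these data alone, is whether the group on this aromatic nitrogen can matter at all for this read-out, as long as nearly every value stays a limit rather than a number.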